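Swapping the aryl substituent on a fused thiazole-type core

This account rests on a few compounds, and the source may have more. Where it says the series, first, only, none or still open, it means among the compounds named here.

Measured so far:
compound 1, `COc1ccc(-c2nn3cc(-c4cccc(N)c4)nc3s2)cc1OC`: 16000 nM
compound 2, `C=C(Br)C(=O)Nc1cccc(-c2cn3nc(Cc4cccc(OC)c4)sc3n2)c1`: 2000 nM
compound 3, `COc1cccc(Cc2nn3cc(-c4cccc(N)c4)nc3s2)c1`: 21000 nM

In a functional assay on L1210 cells (Mus musculus) for inhibition, read by cell counting, with a stated time of 2 days (a lower number here means a stronger inhibitor, a higher number a weaker inhibitor), compound 2 gives 2000 nM, the lowest number of the three and the most potent compound here, since its gaps to compound 1 and compound 3 both lie beyond the scatter. For the measured compounds named here, the one step among the measured compounds, an 11-fold higher number from compound 2 to compound 3 (1.02 log units; beyond the scatter), concerns the amide side of the molecule and does not touch the change now at hand. Compound 4, `C=C(Br)C(=O)Nc1cccc(-c2cn3nc(-c4ccc(CC)cc4)sc3n2)c1`, differs from compound 2 at the other end: 4-ethylphenyl in place of 3-methoxybenzyl on an aromatic carbon. Going by the values given here, no measured step bears directly on this change. Compound 1 gives 16000 nM and compound 3 gives 21000 nM; these two compounds carry an aryl and a benzyl group at that position, and their two numbers lie within the scatter of each other, suggesting that this position tolerates such a swap without a large shift. Compound 4 is therefore expected to stay close to compound 2, with a step of a 1.3-fold higher number from compound 2 to compound 4 (0.10 log units; within the scatter) that need not exceed the scatter. The estimate for compound 4 is 2500 nM, in a range from 800 nM to 8000 nM.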

Compound 4, half-maximal inhibitory concentration: 2200 nM
For compound 4 the middle estimate is 1.1-fold (0.06 log units) above the measured one; the measured number falls inside the stated range.
By their numbers in this assay, from the lowest: compounds 2 and 4 (each within the scatter of the next); then compounds 1 and 3 (each within the scatter of the next).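

In this assay, for the compounds shown here, putting 4-ethylphenyl in place of 3-methoxybenzyl on the aromatic carbon next to the ring sulfur gives a 1.1-fold higher number from compound 2 to compound 4 (0.04 log units; within the scatter), the first measured step at this position, and it shows that compound 2 and compound 4 cannot be told apart with the (1-bromoethenyl)carbonyl group present on the nitrogen. Compound 4 has neither the methoxy oxygen nor the benzyl carbon link, so neither feature is required to hold the number within the scatter of compound 2. Nothing available explains why this exchange is tolerated.

As far as these compounds go, it remains open whether this tolerance extends to a phenyl ring bearing an amine or a carboxylic acid, or to a longer chain in place of ethyl. From the compounds shown here alone, it is also open how 4-ethylphenyl behaves when hydrogen replaces the (1-bromoethenyl)carbonyl group.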